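Does the Propoxy Gain Carry Over to Compound 4?

This account rests on a few compounds, and the source may have more. Where it says the series, first, only, none or still open, it means among the compounds named here.

Compound 1 `COC(=O)C1=C(C)NC(=O)NC1c1cccs1` and compound 2 `CCCOC(=O)C1=C(C)NC(=O)NC1c1cccs1` share one core and differ only in ethyl in place of hydrogen on a saturated chain carbon bound to an oxygen next to a carbonyl group. In an assay on membranes from CHO cells for displacement of a labelled ligand from adenosine receptor A1 (Homo sapiens), read by scintillation counting, with a stated time of 60 min, tested at 1 uM (on this read-out higher numbers stand for more inhibition at the one concentration tested (going by the name of the read-out) and lower numbers for less inhibition), compound 1 gives 6%, while compound 2 gives 43%, a change of a number 37 percentage points higher from compound 1 to compound 2 (beyond the scatter). Compound 3 `COC(=O)C1=C(C)NC(=S)NC1c1ccsc1` is built on another core; the difference between the two cores is not broken down here. In this assay compound 3 gives 3%, which is within the scatter of compound 1. Compound 4 `CCCOC(=O)C1=C(C)NC(=S)NC1c1ccsc1` carries the same change applied to compound 3, namely (ethyl in place of hydrogen on a saturated chain carbon bound to an oxygen next to a carbonyl group), and the two places match word for word. Because of a number 37 percentage points higher from compound 1 to compound 2 (beyond the scatter), compound 4 is expected to move upward by a number 27 percentage points higher from compound 3 to compound 4 (beyond the scatter), though with a changed core the step is estimated somewhat smaller and with wide uncertainty. Compound 4 is therefore estimated at about 30%, plausibly between 8% and 55%.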

Compound 4, a percentage reported as inhibition, at one concentration (the size of the read-out at that concentration, not a potency): 5%
The estimate for compound 4 lay 25 percentage points above the measured number, outside the stated range (below it).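

On the core of compound 3, the change from methoxycarbonyl to propoxycarbonyl gives a number 2 percentage points higher from compound 3 to compound 4 (within the scatter) in this assay, so the gain seen on the core of compound 1 does not carry over to this core. The same change thus behaves differently on the two cores: the same change on two cores in this assay, a number 37 percentage points higher (beyond the scatter) from compound 1 to compound 2 and a number 2 percentage points higher (within the scatter) from compound 3 to compound 4, 35 percentage points apart, beyond the scatter of two such steps

This rests on a single pair on each core, and it does not show which feature of the core of compound 3 accounts for the difference, nor how the change would behave on any other core. As far as these compounds go, it remains open whether a longer chain, such as butoxycarbonyl, would raise the number on the core of compound 3. Ethoxycarbonyl, with a chain intermediate between methoxycarbonyl and propoxycarbonyl, also remains open on both cores.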